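The source may hold more compounds than are shown below. What is called first, only, known or untested is meant among the compounds shown, and "the series" means these compounds.

Of the compounds shown here, three have numbers so far in a functional assay on HT-29 cells (Homo sapiens) for cytotoxicity, read by MTT assay, with a stated time of 72 h; on this read-out higher numbers stand for weaker inhibition of growth and lower numbers for stronger inhibition of growth. Compound 1 `CSc1ccc(CNc2nc(SC)nc3ncccc23)cc1` gives 4320 nM, the lowest of the three. Compound 3 `Sc1nc(NCc2ccccc2)c2ccccc2n1` gives 10100 nM, a gap beyond the scatter, and compound 2 `CSc1nc(Nc2ccccc2)c2ccccc2n1` gives 65800 nM, the furthest from compound 1. Compound 4 `CSc1nc(NCc2ccccc2)c2cccnc2n1` has not been measured in this assay. It differs from compound 1 by hydrogen in place of methylsulfanyl on an aromatic carbon. No pair of measured compounds that differ in a single place is available, so the size of this change is not anchored by any shown comparison; the expectation is a small rise in the number, at the edge of the scatter. For compound 4 the estimated value is 7500 nM, with a range of 3000 nM to 19000 nM. This corresponds to an expected step of a 1.7-fold higher number from compound 1 to compound 4 (0.24 log units; within the scatter).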

Compound 4, concentration for 50% growth inhibition: 87100 nM
Beside the measured number, compound 4's estimate is 12-fold (1.06 log units) below it; measured number above the stated range.
By their numbers in this assay, from the lowest: compound 1; then compound 3; then compounds 2 and 4 (each within the scatter of the next).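

Replacing methylsulfanyl with hydrogen on this aromatic carbon, para to a large group, gives a 20-fold higher number from compound 1 to compound 4 (1.30 log units; beyond the scatter) in this assay, a large step. Within the data shown here, this is the first single-place comparison, and it shows that the read-out is highly sensitive to the group at this position. No available measurement explains the size of this step.

Going by these compounds, whether methoxy, chlorine or an amine at this position would retain the lower number remains open. So does whether a longer chain on the sulfur would do so.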